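Aryl variation on the shared core: toward compound 4

The source may report more compounds than this note shows. Statements on the series, on what has been measured and on what is new or still open speak of the compounds shown alone.

For the measured compounds named here, compound 3 `Fc1ccccc1-c1cn2ccnc2c(-c2ccc3ncn(C4CCCCC4)c3c2)n1` stands second highest of the three numbers so far in a functional assay on U-251 cells (Homo sapiens) for inhibition, read by sulforhodamine B assay, with a stated time of 48 h, tested at 10 uM (on this read-out lower numbers stand for less inhibition and higher numbers for more inhibition at the one concentration tested (going by the name of the read-out)), where compound 3 gives 11.4%. Its nearest neighbour is compound 2 `Clc1ccc(-c2cn3ccnc3c(-c3ccc4ncn(C5CCCCC5)c4c3)n2)cc1`, which gives 11.3% in this assay; the two lie within the scatter, the step being a number 0.1 percentage points higher from compound 2 to compound 3 (within the scatter). Furthest away is compound 1 `COc1ccc(-c2cn3ccnc3c(-c3ccc4ncn(C5CCCCC5)c4c3)n2)cc1`, the only one of the three carrying a 4-methoxyphenyl group, which gives 80.9% in this assay; the drops from it are a number 69.6 percentage points lower from compound 1 to compound 2 (beyond the scatter) and a number 69.5 percentage points lower from compound 1 to compound 3 (beyond the scatter).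

Compound 4 `FC(F)(F)c1cccc(-c2cn3ccnc3c(-c3ccc4ncn(C5CCCCC5)c4c3)n2)c1` is not yet measured. It differs from compound 3 in one place: 3-(trifluoromethyl)phenyl in place of 2-fluorophenyl on an aromatic carbon.

Of the measured steps, a number 0.1 percentage points higher from compound 2 to compound 3 (within the scatter) is the one that bears most directly on this change, as it too swaps one substituted phenyl ring for another without touching the rest of the core, and it was within the scatter. Going by the values given here, the two large steps, a number 69.6 percentage points lower from compound 1 to compound 2 (beyond the scatter) and a number 69.5 percentage points lower from compound 1 to compound 3 (beyond the scatter), both start from the methoxy compound and say nothing about a trifluoromethyl group, which no measured compound carries. A step of no more than the scatter, a number 3.6 percentage points higher from compound 3 to compound 4 (within the scatter), is therefore expected in this assay. Compound 4 is estimated at 15% in this assay. Compound 4 is expected to fall between 3% and 45% in this assay. The upper end is left wide because compound 1 has shown a high number in 80.9% in this assay.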

Compound 4, a percentage reported as inhibition, at one concentration (the size of the read-out at that concentration, not a potency): 5.93%
Estimate against measurement, compound 4: 9.1 percentage points above; the measured number falls inside the stated range.
By their numbers in this assay, from the lowest: compounds 4, 2 and 3 (each within the scatter of the next); then compound 1.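

In this assay, 3-(trifluoromethyl)phenyl at this position, on the aromatic carbon next to the ring nitrogen, gives a number 5.5 percentage points lower from compound 3 to compound 4 (within the scatter) and a number 5.4 percentage points lower from compound 2 to compound 4 (within the scatter), so a third non-methoxy aryl group joins 2-fluorophenyl and 4-chlorophenyl, and the larger group with three fluorines does not separate from them. For the compounds shown here, the step of a number 75 percentage points lower from compound 1 to compound 4 (beyond the scatter) is large, which leaves compound 1 as the only one of the four compounds standing apart; the earlier compounds showed this gap against only two aryl groups, both carrying a single halogen. No measurement shown gives a reason for the separate standing of the 4-methoxyphenyl group.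

From the compounds shown here alone, it remains open whether the high number of compound 1 depends on the methoxy group itself or on its place on the phenyl ring, and whether a 3-methoxyphenyl, 4-ethoxyphenyl, 4-hydroxyphenyl or 4-(dimethylamino)phenyl group would keep it. Going by these compounds alone, all four compounds carry the same cyclohexyl group and each has only a single reading at one concentration, so the effect of another group at that site and any potency at this position also remain open.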